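Ethyl in Place of Isopropyl on the Amide Nitrogen

The source may hold more compounds than are shown below. What is called first, only, known or untested is meant among the compounds shown, and "the series" means these compounds.

Compound 1, `O=C(/C=C1\CCc2c1ccc(F)c2F)NC1CC1`: 62 mg/kg
Compound 2, `CC(C)NC(=O)/C=C1\CCc2ccc(F)cc21`: 96 mg/kg
Compound 3, `NC(=O)/C=C1\CCc2c(F)cc(F)cc21`: 69 mg/kg

Of the compounds shown here, three have been tested in a functional assay on the whole organism with Mus musculus as the target; on this read-out lower numbers stand for an effect already at smaller amounts and higher numbers for an effect only at larger amounts of compound. Compound 2 stands at the highest of the three numbers, but its neighbours lie close: the gap to compound 3 is within the usual scatter, and so is the gap to compound 1, so no ordering among the three can be claimed. All three therefore sit in the same region of this assay.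

Compound 4, `CCNC(=O)/C=C1\CCc2ccc(F)cc21`, has not yet been tested. It is compound 2 with one change: hydrogen in place of methyl on a saturated chain carbon bound to an amide-type nitrogen and a saturated chain carbon. The alkyl group on the amide nitrogen is thus trimmed from isopropyl to ethyl, while the core and its fluorine substitution are untouched.

Among the compounds with values here, no step between two measured compounds isolates this kind of change, so there is nothing in the data to anchor its effect. Given how tightly the three measured values cluster, the step from compound 2 to compound 4 is expected to be a 1.2-fold lower number from compound 2 to compound 4 (0.08 log units; within the scatter), that is, no movement beyond the scatter in either direction. Compound 4 is accordingly estimated at 80 mg/kg, with a likely range from 40 mg/kg to 160 mg/kg.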

Compound 4, dose for half-maximal effect: 70 mg/kg
The estimate for compound 4 lay 1.1-fold (0.06 log units) above the measured number; the range from low to high includes it.
By their numbers in this assay, from the lowest: compounds 1, 3, 4 and 2 (each within the scatter of the next).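

The only step among these compounds that isolates a single change, isopropyl to ethyl on a saturated chain carbon bound to an amide-type nitrogen, gives a 1.4-fold lower number from compound 2 to compound 4 (0.14 log units; within the scatter) in this assay. On this one pair, the read-out therefore does not separate the two alkyl groups, and the loss of a methyl at this place leaves no change that can be told from the scatter. Nothing available on these compounds offers an explanation for this result.

Whether a larger change at this place would move the number stays open, as the compounds shown include no longer chain such as butyl and no chain ending in an amine or a carboxylic acid on the amide-type nitrogen. Compound 1 and compound 3 differ from compound 2 and compound 4 both in the group on that nitrogen and in the fluorine substitution of the core, so the contribution of each of these two places to their values cannot be separated.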